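The source may hold more compounds than are shown below. What is called first, only, known or untested is meant among the compounds shown, and "the series" means these compounds.

Measured so far in a functional assay on CHO-K1 cells for antagonist activity at transient receptor potential cation channel subfamily V member 1 (Homo sapiens), read by FLIPR; a lower number here means a stronger inhibitor, a higher number a weaker inhibitor:
compound 1 `CCCN(CCC)c1nc(C(F)(F)F)ccc1CNC(=O)C(C)c1ccc(NS(C)(=O)=O)c(F)c1` gives 14.7 nM;
compound 2 `CC(C(=O)NCc1ccc(C(F)(F)F)nc1N1CCCC1)c1ccc(NS(C)(=O)=O)c(F)c1` gives 211 nM;
compound 3 `CC(C(=O)NCc1ccc(C(F)(F)F)nc1N1CCC(C(F)(F)F)CC1)c1ccc(NS(C)(=O)=O)c(F)c1` gives 31 nM.

Of these three numbers compound 3 holds the second place, set by a 2.1-fold higher number from compound 1 to compound 3 (0.32 log units; beyond the scatter) and by a 6.8-fold lower number from compound 2 to compound 3 (0.83 log units; beyond the scatter). Compound 4 `COC1CCN(c2nc(C(F)(F)F)ccc2CNC(=O)C(C)c2ccc(NS(C)(=O)=O)c(F)c2)CC1` differs from compound 3 in one spot: methoxy in place of trifluoromethyl on a saturated ring carbon. Within the data shown here, no measured step swaps a group on that saturated ring, so the bearing is indirect. The steps that vary the amine on the aromatic carbon, a 14-fold higher number from compound 1 to compound 2 (1.16 log units; beyond the scatter) and a 6.8-fold lower number from compound 2 to compound 3 (0.83 log units; beyond the scatter), show that this region of the molecule shifts the read-out in this assay considerably. A modest weakening is therefore expected, a 1.9-fold higher number from compound 3 to compound 4 (0.29 log units; within the scatter). Compound 4 is estimated at 60 nM, in a range from 20 nM to 200 nM.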

Compound 4, half-maximal inhibitory concentration: 280 nM
The estimate for compound 4 lay 4.7-fold (0.67 log units) below the measured number; the measured number lies above the stated range.
By their numbers in this assay, from the lowest: compound 1; then compound 3; then compounds 2 and 4 (each within the scatter of the next).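

In this assay, the group on the saturated ring carbon proves as decisive as the choice of amine: methoxy in place of trifluoromethyl gives a 9.0-fold higher number from compound 3 to compound 4 (0.96 log units; beyond the scatter) on an otherwise unchanged molecule. The 4-methoxypiperidin-1-yl group thus gives no gain over pyrrolidin-1-yl (a 1.3-fold higher number from compound 2 to compound 4 (0.12 log units; within the scatter)) and falls well short of dipropylamino (a 19-fold higher number from compound 1 to compound 4 (1.28 log units; beyond the scatter)). Nothing measured here explains the loss. Open, on these data alone, is whether a methyl, a hydroxyl or an ethoxy on that ring carbon would read closer to compound 3 or to compound 4.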